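The source may hold more compounds than are shown below. What is called first, only, known or untested is meant among the compounds shown, and "the series" means these compounds.

Working notes on the series. Of the compounds shown here, three have been tested in a functional assay on the whole organism for inhibition, with Mus musculus as the target, at a dose of 25 mg/kg by the oral route; a higher number here means more inhibition at the dose given (going by the name of the read-out), a lower number less inhibition. Compound 1 `Fc1cccc(N2CCN(CCCOc3ccc4c(c3)CCC4)CC2)c1` gives 42% in this assay. Compound 2 `Fc1cccc(N2CCN(CCCCOc3ccc4c(c3)CCC4)CC2)c1` gives 17% in this assay, the lowest of the three numbers. Compound 3 `Fc1ccc(N2CCN(CCCCCOc3ccc4c(c3)CCC4)CC2)cc1` gives 71% in this assay. Compound 2 therefore stands at the bottom: its nearest neighbour is compound 1, whose number is higher by a margin beyond the scatter, and compound 3 lies further off, also beyond the scatter. Going by the values given here, compound 3 differs from compound 2 in more than one place, so the two values show only that the pair sits far apart.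

Compound 4 `Clc1ccc(N2CCN(CCCCOc3ccc4c(c3)CCC4)CC2)cc1` has not yet been measured. It differs from compound 2 in one place: 4-chlorophenyl in place of 3-fluorophenyl on an amine nitrogen in a ring. Among the compounds with values here, no pair of measured compounds differing only in this way is available, so the step is uncharted. A modest change is expected, most likely upward but possibly none beyond the scatter, giving an expected step of a number 13 percentage points higher from compound 2 to compound 4 (beyond the scatter). The estimate for compound 4 in this assay is 30%, within a range from 10% to 60%.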

Compound 4, a percentage reported as inhibition, in the whole organism at one dose (the size of the read-out at that dose, not a potency): 33%
Estimate against measurement, compound 4: 3 percentage points below; the measured number falls inside the stated range.
By their numbers in this assay, from the lowest: compound 2; then compounds 4 and 1 (each within the scatter of the next); then compound 3.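

In this assay, going by these compounds alone, the aryl group on the amine nitrogen in the ring now has a first reading at a single place: 4-chlorophenyl in place of 3-fluorophenyl gives a number 16 percentage points higher from compound 2 to compound 4 (beyond the scatter), a modest step with the rest of the structure held fixed. The two groups match in heavy-atom count and in having no hydrogen-bond donors or acceptors, yet the read-out moves, so this position is not silent in the whole-organism assay. Nothing on hand accounts for the size or direction of the step.

The swap changes both the halogen, fluorine to chlorine, and its place on the ring, and the compounds shown do not separate these two changes. Also open, on these data alone, are how an unsubstituted phenyl or a pyridine ring would read on this nitrogen, and whether the step carries over to the other chain lengths in compounds 1 and 3.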